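The compounds below may be only part of what the source reports. "The series", "measured", "known", "first", "only" and "open" are said of these compounds alone.

Measured in a functional assay on A549 cells (Homo sapiens) for antiproliferative activity, read by MTT assay, with a stated time of 48 h; on this read-out higher numbers stand for weaker inhibition and lower numbers for stronger inhibition:
- Compound 1 `Cc1cc2nc(NC(c3cn(-c4ccccc4)nc3-c3ccc([N+](=O)[O-])cc3)c3c(O)ccc4ccccc34)sc2cc1C`: 41900 nM
- Compound 2 `O=[N+]([O-])c1cccc(-c2nn(-c3ccccc3)cc2C(Nc2nc3ccc(Cl)cc3s2)c2c(O)ccc3ccccc23)c1`: 42500 nM

Compound 2 gives 42500 nM, and compound 1 gives 41900 nM. These two values lie within the usual scatter of each other, so they cannot be told apart.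

Compound 3 `O=[N+]([O-])c1ccc(-c2nn(-c3ccccc3)cc2C(Nc2nc3ccc(Cl)cc3s2)c2c(O)ccc3ccccc23)cc1` has not yet been measured. It has 4-nitrophenyl in place of the 3-nitrophenyl of compound 2 on an aromatic carbon (4-nitrophenyl in place of 3-nitrophenyl on an aromatic carbon). The two compounds have the same atoms, joined differently.

Within the data shown here, no measured pair shows this change on its own. Compound 1 also carries 4-nitrophenyl, though it differs from compound 3 at another place, and compound 1 gives 41900 nM. In this assay, no step beyond the scatter is therefore expected, in either direction. The expected change is a 1.1-fold lower number from compound 2 to compound 3 (0.03 log units; within the scatter). For compound 3, the estimated value is 40000 nM, with an expected range of 18000 nM to 80000 nM.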

Compound 3, half-maximal inhibitory concentration: 57200 nM
Compound 3: middle estimate off by 1.4-fold (0.16 log units), on the low side; the range from low to high includes it.
By their numbers in this assay, from the lowest: compounds 1, 2 and 3 (each within the scatter of the next).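

In this assay, putting 4-nitrophenyl in place of 3-nitrophenyl on the aromatic carbon of the five-membered ring gives a 1.3-fold higher number from compound 2 to compound 3 (0.13 log units; within the scatter), so this first direct test of the change finds no difference that can be told apart from the scatter. With 4-nitrophenyl held in place, 6-chloro-1,3-benzothiazol-2-yl in place of 5,6-dimethyl-1,3-benzothiazol-2-yl on the amine nitrogen gives a 1.4-fold higher number from compound 1 to compound 3 (0.14 log units; within the scatter), so the chloro and dimethyl groups cannot be told apart here either. No measured evidence explains these results.

On these data alone, all three compounds carry a nitrophenyl group at this position, so the effect of a plain phenyl group, or of a phenyl ring bearing an amine or a carboxylic acid instead of the nitro group, remains open. As far as these compounds go, whether the 5,6-dimethyl and 6-chloro groups would also match when paired with 3-nitrophenyl also remains open.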